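Para-substituent variation on the aryl triazole nucleoside series

The source may report more compounds than this note shows. Statements on the series, on what has been measured and on what is new or still open speak of the compounds shown alone.

Measured so far:
compound 1 `CC(C)c1ccc(-n2cc(-c3cn([C@H]4C[C@H](O)[C@@H](CO)O4)c(=O)[nH]c3=O)nn2)cc1` — 6200 nM
compound 2 `CCCCc1ccc(-n2cc(-c3cn([C@H]4C[C@H](O)[C@@H](CO)O4)c(=O)[nH]c3=O)nn2)cc1` — 23000 nM
compound 3 `O=c1[nH]c(=O)n([C@H]2C[C@H](O)[C@@H](CO)O2)cc1-c1cn(-c2ccc(Br)cc2)nn1` — 1370 nM

The three compounds share one core and differ only in the group on the para position of the aryl ring carried by the triazole. In an ADME assay on HeLa cells (Homo sapiens) for cytotoxicity, read by cell counting, with a stated time of 4 days (on this read-out higher numbers stand for weaker inhibition and lower numbers for stronger inhibition), compound 3 stands lowest of the three; the step of a 4.5-fold lower number from compound 1 to compound 3 (0.66 log units; beyond the scatter) and the step of a 17-fold lower number from compound 2 to compound 3 (1.23 log units; beyond the scatter) both lie beyond the scatter, so compound 3 is the strongest inhibitor of the set. Between the two alkyl members the step of a 3.7-fold higher number from compound 1 to compound 2 (0.57 log units; beyond the scatter) shows that the longer chain goes with the higher number.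

Compound 4 `O=c1[nH]c(=O)n([C@H]2C[C@H](O)[C@@H](CO)O2)cc1-c1cn(-c2ccc(Oc3ccccc3)cc2)nn1` has not yet been measured. It arises from compound 3 by the change (phenoxy in place of bromo on an aromatic carbon). Among the measured compounds shown here, no measured step exchanges bromo for an aryl ether, so the bearing of the known steps is indirect: both the step from isopropyl to bromo and the step from butyl to bromo went down, and the larger of the two alkyl groups gave the higher number. A group of seven heavy atoms entering in place of the single bromine is therefore expected to move this assay upward, by about a 3.6-fold higher number from compound 3 to compound 4 (0.56 log units; beyond the scatter). Compound 4 is estimated at 5000 nM, within a range of 1500 nM to 20000 nM.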

Compound 4, half-maximal inhibitory concentration: 280 nM
Compound 4: the middle estimate sits 18-fold (1.25 log units) above what was measured; the whole stated range lies above it.
By their numbers in this assay, from the lowest: compound 4; then compound 3; then compound 1; then compound 2.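

In this assay the phenoxy group takes the series lower still, a 4.9-fold lower number from compound 3 to compound 4 (0.69 log units; beyond the scatter), so compound 4 is the strongest inhibitor of the four and bromo no longer marks the low end at this position. The gaps to the alkyl members are wider, a 22-fold lower number from compound 1 to compound 4 (1.35 log units; beyond the scatter) and an 82-fold lower number from compound 2 to compound 4 (1.91 log units; beyond the scatter), so the earlier pairing of a larger alkyl group with a higher number does not extend to every large group on this aromatic carbon; compound 4 goes against it. No supporting data explain the difference between phenoxy and the other groups.

Going by these compounds, whether the drop belongs to the ether oxygen or to the added aromatic ring stays open; a phenyl or a benzyl group at this place would separate the two. Also open, on these data alone, is how a chlorine or a methoxy group on the outer ring of phenoxy would move the number.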